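Working notes: methyl pattern on the aryl ring and dose

The source may report more compounds than this note shows. Statements on the series, on what has been measured and on what is new or still open speak of the compounds shown alone.

compound 1 `O=C(CN1CCN(c2ccccc2)CC1)N(c1ccccc1)c1ccccc1` — 20.5 mg/kg
compound 2 `Cc1ccc(N2CCN(CC(=O)N(c3ccccc3)c3ccccc3)CC2)cc1` — > 20 mg/kg

In a functional assay on the whole organism (strain Swiss albino) for inhibition, with Mus musculus as the target, with stated times of 10 min, 5 min and 20 min (a higher number here means that more compound is needed for the effect, a lower number that less compound is needed), compound 1 gives 20.5 mg/kg. For compound 2 the value > 20 mg/kg is a limit of this assay and not a number. Compound 2 therefore stands only at a limit in this assay, with no exact dose known. The step that the limit leaves unreadable from compound 1 to compound 2 cannot be read, because the limit of > 20 mg/kg in this assay, at which 1 of the 2 values shown sits, covers one of the two values.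

Compound 3 `Cc1cccc(N2CCN(CC(=O)N(c3ccccc3)c3ccccc3)CC2)c1C` differs from compound 2 by 2,3-dimethylphenyl in place of 4-methylphenyl on an amine nitrogen in a ring. Among the compounds with values here, the only measured step, from compound 1 to compound 2, bears on a methyl on the same aryl ring, but its size is not readable, so it gives no direction for the present change. With no readable step, the expectation for compound 3 is that it stays near where compound 2 stands, and the step that the limit leaves unreadable from compound 2 to compound 3 is expected to be small or unreadable. Compound 3 is thus expected to give 25 mg/kg in this assay, with a range from 12 mg/kg to 60 mg/kg, and a sizeable chance that only a limit is reported.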

Compound 3, dose for half-maximal effect: 28.5 mg/kg
For compound 3 the middle estimate is 1.1-fold (0.06 log units) below the measured one; measured number inside the range.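

In this assay, within the data shown here, there is now a 1.4-fold higher number from compound 1 to compound 3 (0.14 log units; within the scatter) for 2,3-dimethylphenyl in place of phenyl on the amine nitrogen in the ring, the first readable step at this position, and it does not separate the two compounds. The earlier pair could not show this: one methyl-bearing aryl pattern at this place can now be compared with the unsubstituted phenyl, and the two doses lie level within the scatter. For compound 2 the entry > 20 mg/kg is a limit and not a number, and the steps from compound 1 to it and from it to compound 3 cannot be read, so 4-methylphenyl cannot be placed against the other two groups: the limit of > 20 mg/kg in this assay, at which 1 of the 3 values shown sits.

The compounds shown hold only carbon substituents on this aryl ring, and how a methoxy group, a chlorine or a carboxylic acid there would shift the dose stays open. Also open, going by these compounds, is whether a pyridine ring in place of this phenyl, or an amine on a longer chain at the same place, would give a step beyond the scatter in this assay at all.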